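A Fluoro on the 4-Methoxybenzyl Group of Compound 1

This account rests on a few compounds, and the source may have more. Where it says the series, first, only, none or still open, it means among the compounds named here.

Measured so far in a functional assay on HCT-116 cells (Homo sapiens) for inhibition, read by CCK-8 assay, with a stated time of 48 h; on this read-out lower numbers stand for stronger inhibition and higher numbers for weaker inhibition:
- Compound 1 `COc1ccc(CN(C(=O)CSC(=S)N2CCN(C(=O)OC(C)(C)C)CC2)c2cc(OC)c(OC)c(OC)c2)cc1`: 620 nM
- Compound 2 `COc1ccc(CN(C(=O)CSC(=S)N2CCN(C(=O)OC(C)(C)C)CC2)c2ccc(OC)cc2)cc1`: > 20000 nM (a limit)

Within the data shown here, compound 1 holds the only actual number in this assay, at 620 nM. Compound 2 reads > 20000 nM, which is a limit of the assay and not a number.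

Compound 3 `COc1ccc(CN(C(=O)CSC(=S)N2CCN(C(=O)OC(C)(C)C)CC2)c2cc(OC)c(OC)c(OC)c2)cc1F` is compound 1 with a single change: fluoro in place of hydrogen on an aromatic carbon. Fluoro takes the place of hydrogen on an aromatic carbon, ortho to a methoxy group, so 4-methoxybenzyl becomes 3-fluoro-4-methoxybenzyl.

Among the measured compounds shown here, the one measured step, an at least 32-fold higher number from compound 1 to compound 2 (1.50 log units; beyond the scatter), is large, but it replaces 3,4,5-trimethoxyphenyl on an amide-type nitrogen and leaves the 4-methoxybenzyl group untouched. For the measured compounds named here, it therefore sets no size for the fluoro change, and no measured step tests that group. The best anchor remains compound 1 at 620 nM.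

In this assay, no step beyond the scatter is expected, and the estimated change is a 1.1-fold higher number from compound 1 to compound 3 (0.05 log units; within the scatter). For compound 3 the estimated value is 700 nM, with an expected range from 220 nM to 2500 nM.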

Compound 3, half-maximal inhibitory concentration: 8210 nM
Estimate against measurement, compound 3: 12-fold (1.07 log units) below; the measured number lies above the stated range.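

In this assay, fluoro in place of hydrogen on an aromatic carbon, ortho to a methoxy group, gives a 13-fold higher number from compound 1 to compound 3 (1.12 log units; beyond the scatter). Among these compounds, this is the first measured sign that the 4-methoxybenzyl group matters as well as the 3,4,5-trimethoxyphenyl group on the amide-type nitrogen, and it shows that one added heavy atom on this ring is enough to produce a large step. Unlike compound 2, compound 3 still gives an actual number, so this loss can be sized, while the one limit among the values stays a limit and nothing more: the limit of > 20000 nM in this assay, at which 1 of the 3 values shown sits.

The compounds shown leave open whether chloro, methyl or hydroxyl on this same aromatic carbon would give a step of similar size, or whether the step belongs to fluoro alone. They also leave open what lies behind the step, and whether fluoro on another carbon of the 4-methoxybenzyl ring, or a hydroxyl in place of its methoxy group, would be tolerated any better in this assay.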